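The source may hold more compounds than are shown below. What is called first, only, known or untested is meant among the compounds shown, and "the series" means these compounds.

The series is followed in a functional assay on CHO cells for inhibition of Orexin/Hypocretin receptor type 1 (Homo sapiens), read by FLIPR and calcium flux; on this read-out lower numbers stand for stronger inhibition and higher numbers for weaker inhibition. Compound 1 `CCN(CC)C(=O)CN(c1ccc(C)cc1)S(=O)(=O)c1ccc(OC)c(OC)c1` stands only at a limit of that read-out: in this assay compound 1 gives > 10000 nM, which is the limit of > 10000 nM in this assay, at which 1 of the 2 values shown sits. Among the measured compounds shown here, compound 2 `CCN(C(=O)CN(c1cc(N(C)C)ccc1Cl)S(=O)(=O)c1ccc(OC)c(OC)c1)c1cnc(C)cn1` carries a different amide and a different aryl group on the sulfonamide nitrogen, so no single-point step joins it to compound 1; in this assay compound 2 gives 5 nM. Their two values show one compound at the limit and one with strong inhibition.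

Compound 3 `CCN(CC)C(=O)CN(c1cc(C(C)C)ccc1Cl)S(=O)(=O)c1ccc(OC)c(OC)c1` has not yet been measured. It differs from compound 1 in one place: 2-chloro-5-isopropylphenyl in place of 4-methylphenyl on a sulfonamide nitrogen. The diethylamide of compound 1 is retained. A step towards stronger inhibition beyond the scatter is expected, since compound 2, which also bears a 2-chloro-5-substituted phenyl on the sulfonamide nitrogen, gives 5 nM. For compound 3 the expected step is an at least 20-fold lower number from compound 1 to compound 3 (1.30 log units; beyond the scatter). For compound 3 the estimate is 500 nM, within 50 nM to 5000 nM.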

Compound 3, half-maximal inhibitory concentration: 888 nM
Compound 3: the middle estimate sits 1.8-fold (0.25 log units) below what was measured, and the stated range covers the measured number.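

In this assay, with the diethylamide of compound 1 retained, 2-chloro-5-isopropylphenyl in place of 4-methylphenyl on the sulfonamide nitrogen gives an at least 11-fold lower number from compound 1 to compound 3 (1.05 log units; beyond the scatter). Among the compounds shown here, this is the first single-place comparison, and it shows that changing the aryl group at this position alone is enough to bring a compound from the limit to a measurable number. The size of the step can be read only as a minimum because compound 1 stands at a limit: the limit of > 10000 nM in this assay, at which 1 of the 3 values shown sits.

The compounds shown do not separate the contribution of the chlorine from that of the isopropyl group, as both enter in the same step. Also open, from the compounds shown here alone, is what a tert-butyl or a methoxy group in place of the isopropyl group would give with the diethylamide retained.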